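Chain change from compound 3 to compound 4

A few compounds are considered here, and "the series" means these few. Any claim that something is new, unique, unknown or untested is made for them only; others in the source may bear on it.

compound 1 `CCOC(=O)c1cc(N2C(=O)C3=C(CCCC3)C2=O)ccc1Cl` gives 1380 nM
compound 2 `CC(C)OC(=O)c1cc(N2C(=O)C3=C(CCCC3)C2=O)ccc1Cl` gives 1000 nM
compound 3 `CC(C)COC(=O)c1cc(N2C(=O)C3=C(CCCC3)C2=O)ccc1Cl` gives 759 nM

In a functional assay on the whole organism with Scenedesmus acutus as the target (a higher number here means a weaker inhibitor, a lower number a stronger inhibitor), compound 3 gives 759 nM and stands within the scatter of both other compounds, with a 1.8-fold lower number from compound 1 to compound 3 (0.26 log units; within the scatter) and a 1.3-fold lower number from compound 2 to compound 3 (0.12 log units; within the scatter) as its steps. The difference from compound 3 to the unmeasured compound 4 `CCCCCOC(=O)c1cc(N2C(=O)C3=C(CCCC3)C2=O)ccc1Cl` is butyl in place of isopropyl on a saturated chain carbon bound to an oxygen next to a carbonyl group and reads, one bond further out, as isobutyl to pentyl. The measured steps bearing on it are changes in the same chain: a 1.4-fold lower number from compound 1 to compound 2 (0.14 log units; within the scatter) joins the two above, and all three stay within the scatter. In this assay no step beyond the scatter is therefore expected, and the estimate means a 1.1-fold lower number from compound 3 to compound 4 (0.04 log units; within the scatter) as the expected step. For compound 4 the estimated value is 700 nM with an expected range from 350 nM to 1400 nM on this evidence.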

Compound 4, half-maximal inhibitory concentration: 9330 nM
Beside the measured number, compound 4's estimate is 13-fold (1.12 log units) below it; the measured number lies above the stated range.
By their numbers in this assay, from the lowest: compounds 3, 2 and 1 (each within the scatter of the next); then compound 4.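

In this assay the chain on the oxygen next to a carbonyl group tolerates change only up to a point: compound 1, compound 2 and compound 3 stay within the scatter of each other, yet isobutyl to pentyl brings a 12-fold higher number from compound 3 to compound 4 (1.09 log units; beyond the scatter) here. The other two comparisons agree, with a 9.3-fold higher number from compound 2 to compound 4 (0.97 log units; beyond the scatter) and a 6.8-fold higher number from compound 1 to compound 4 (0.83 log units; beyond the scatter) on record, so only pentyl parts from the series. Nothing measured here accounts for this jump.

Pentyl differs from isobutyl in both length and branching, so which of the two matters stays open. A longer chain, or a branched chain such as neopentyl, would separate them.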